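The compounds below may be only part of what the source reports. "The series", "measured", "known", "first", "only" and "open" are said of these compounds alone.

Working notes on the series in an ADME assay on SK-OV-3 cells (Homo sapiens) for cytotoxicity, read by sulforhodamine B assay, with a stated time of 48 h, tested at 10 uM; on this read-out higher numbers stand for more inhibition at the one concentration tested (going by the name of the read-out) and lower numbers for less inhibition.

Three compounds carry the shared core of compound 1 `CCCCCCc1cn(C(c2ccccc2)c2cc3cc(Br)ccc3nc2OC)nn1` and differ only in the group on the triazole carbon. In this assay compound 1 gives 7.17%. Compound 2 `COc1nc2ccc(Br)cc2cc1C(c1ccccc1)n1cc(-c2ccccc2)nn1` carries a phenyl there and in this assay compound 2 gives 13.7%. Compound 3 `CCCCCc1cn(C(c2ccccc2)c2cc3cc(Br)ccc3nc2OC)nn1` carries a pentyl and in this assay compound 3 gives 10.5%. Compound 3 lies between the other two: a number 3.3 percentage points higher from compound 1 to compound 3 (within the scatter) and a number 3.2 percentage points lower from compound 2 to compound 3 (within the scatter), so the three values are not separated from one another.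

Compound 4 `COc1nc2ccc(Br)cc2cc1C(c1ccccc1)n1cc(CCCO)nn1` differs from compound 3 by hydroxy in place of ethyl on a saturated chain carbon, three bonds along the chain from an aromatic carbon. The steps measured so far bear on this only loosely. Shortening the chain, a number 3.3 percentage points higher from compound 1 to compound 3 (within the scatter), and exchanging a pentyl for a phenyl, a number 3.2 percentage points lower from compound 2 to compound 3 (within the scatter), both left the read-out unchanged beyond the scatter. No compound measured carries a hydroxy on the chain, so the effect of the entering group is not shown by any step. The expectation is therefore a step from compound 3 to compound 4 of a number 0.5 percentage points lower from compound 3 to compound 4 (within the scatter), that is, none beyond the scatter. For compound 4 the estimated value in this assay is 10%, with a range from 0% to 25%.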

Compound 4, a percentage reported as inhibition, at one concentration (the size of the read-out at that concentration, not a potency): 13.8%
Beside the measured number, compound 4's estimate is 3.8 percentage points below it, and the stated range covers the measured number.
By their numbers in this assay, from the lowest: compounds 1, 3, 2 and 4 (each within the scatter of the next).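

Hydroxy in place of ethyl on a saturated chain carbon, three bonds along the chain from an aromatic carbon, is the first step in the series that brings a hydrogen-bond donor and a hydrogen-bond acceptor into the chain, and in this assay it gives a number 3.3 percentage points higher from compound 3 to compound 4 (within the scatter), so the read-out does not separate the 3-hydroxypropyl group from the pentyl group. The other two comparisons read the same way, with a number 6.6 percentage points higher from compound 1 to compound 4 (within the scatter) for hydroxy in place of propyl and a number 0.1 percentage points higher from compound 2 to compound 4 (within the scatter) for 3-hydroxypropyl in place of phenyl. At this position the hexyl, pentyl, phenyl and 3-hydroxypropyl groups therefore all lie within the scatter of one another, and nothing at hand offers an account of why they read alike.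

Going by these compounds, what an amine or a carboxylic acid at the end of the chain, or a chain longer than hexyl, would give on the shared core stays open. Also open, on these data alone, is whether these four groups would separate on a potency read-out rather than on the size of the effect at one concentration.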